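Adding a methyl to the phenyl ring of a urea

The compounds below may be only part of what the source reports. "The series", "measured", "known", "first", "only" and "open" are said of these compounds alone.

Of the compounds shown here, two from this series have been measured in an in vivo ADME assay on the whole organism (strain BALB/cAnNCrl) for pharmacokinetics, with Mus musculus as the target, at a dose of 10 mg/kg by the oral route; a higher number here means more compound in the circulation at the dose given, a lower number less compound in the circulation. Compound 1, `Cc1ccc(-n2nc(C(C)(C)C)cc2NC(=O)Nc2ccc(Oc3ccnc4c3[nH]c(=O)n4C)cc2F)cn1`, gives 18000 nM in this assay. Compound 2, `Cn1c(=O)n(C)c2c(Oc3ccc(NC(=O)Nc4cc(C(C)(C)C)nn4-c4ccccc4)c(F)c3)ccnc21`, gives 4440 nM in this assay, which is the lower of the two numbers and lies beyond the usual scatter from compound 1. The two compounds differ in more than one place, so no single structural step accounts for the gap between them; only the two values themselves can be compared.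

Compound 3, `Cc1ccc(-n2nc(C(C)(C)C)cc2NC(=O)Nc2ccc(Oc3ccnc4c3n(C)c(=O)n4C)cc2F)cc1`, has not yet been measured. It is compound 2 with one change: methyl in place of hydrogen on an aromatic carbon. Among the measured compounds shown here, no comparable step between measured compounds exists here, so the expectation rests on the small size of the change alone. The step from compound 2 to compound 3 in this assay is expected to be small, probably within the scatter, with no clear direction, giving a 1.1-fold higher number from compound 2 to compound 3 (0.05 log units; within the scatter). Compound 3 is therefore estimated at 5000 nM, with a range from 1500 nM to 16000 nM.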

Compound 3, maximal plasma concentration: 8120 nM
For compound 3 the middle estimate is 1.6-fold (0.21 log units) below the measured one; measured number inside the range.
By their numbers in this assay, from the lowest: compounds 2 and 3 (each within the scatter of the next); then compound 1.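

In this assay, among the compounds shown here, putting a methyl on an aromatic carbon para to a large group, which turns phenyl into 4-methylphenyl, gives a 1.8-fold higher number from compound 2 to compound 3 (0.26 log units; within the scatter) and is the first change that can be read at a single place. At this position and on this pair, a methyl can therefore be added with no shift that stands out from what repeat measurements of one compound would show, so the change leaves the maximal plasma concentration effectively unmoved. No measurement shown explains this result or says what happens to the compounds in the animal.

On these data alone, one step with one small group says little about the position in general, and it remains open whether a larger or very different group on the same carbon, such as a methoxy group, an amine or a carboxylic acid, would also leave the number within the scatter. The gap to compound 1 also stays unexplained, since that compound differs from the other two in more than one place and its contribution from each place cannot be separated.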